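Working notes: shifting the methylsulfanyl group

The source may report more compounds than this note shows. Statements on the series, on what has been measured and on what is new or still open speak of the compounds shown alone.

Values in a functional assay on HCT-116 cells (Homo sapiens) for antiproliferative activity, read by MTT assay, with a stated time of 72 h; a higher number here means a weaker inhibitor, a lower number a stronger inhibitor:
- compound 1 `C#Cc1cccc(NC(=O)CCc2cccc3c2B(O)OC3)c1`: 3600 nM
- compound 2 `CSc1cccc(-c2cccc(NC(=O)CCc3cccc4c3B(O)OC4)c2)c1`: 110 nM

Compound 2 has the lower of the two numbers, at 110 nM. Compound 3 `CSc1ccc(-c2cccc(NC(=O)CCc3cccc4c3B(O)OC4)c2)cc1` differs from it as follows: 4-(methylsulfanyl)phenyl in place of 3-(methylsulfanyl)phenyl on an aromatic carbon. Within the data shown here, the only measured step, a 33-fold lower number from compound 1 to compound 2 (1.51 log units; beyond the scatter), is large, but it replaces ethynyl with 3-(methylsulfanyl)phenyl and does not test the position of the methylsulfanyl group. Among the measured compounds shown here, no measured pair does, so the direction stays open and only a modest change in this assay is expected. The expected step is a 1.4-fold higher number from compound 2 to compound 3 (0.13 log units; within the scatter). For compound 3 the estimated value is 150 nM, with an expected range of 50 nM to 450 nM.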

Compound 3, half-maximal inhibitory concentration: 180 nM
Beside the measured number, compound 3's estimate is 1.2-fold (0.08 log units) below it; the measured number falls inside the stated range.
By their numbers in this assay, from the lowest: compounds 2 and 3 (each within the scatter of the next); then compound 1.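

In this assay, 4-(methylsulfanyl)phenyl in place of 3-(methylsulfanyl)phenyl gives a 1.6-fold higher number from compound 2 to compound 3 (0.21 log units; within the scatter), so the two placements of the methylsulfanyl group cannot be told apart in this series. The large gain over ethynyl holds for either placement, with a 20-fold lower number from compound 1 to compound 3 (1.30 log units; beyond the scatter), and so does not rest on one placement alone. Nothing on hand accounts for these numbers.

Open, going by these compounds, is whether the methylsulfanyl group contributes at all, or whether a plain phenyl, or a phenyl carrying a methoxy group or an amine, would give similar numbers.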